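Swapping cyclohexylmethyl for 4,4-difluorocyclohexyl on a shared core

This account rests on a few compounds, and the source may have more. Where it says the series, first, only, none or still open, it means among the compounds named here.

- Compound 1 `C=C1C(=O)O[C@H]2CC3=C[C@H](C/C(C)=C/[C@@H](OC(=O)c4ccc(C(F)(F)F)cc4)[C@H]12)OC3=O` gives > 10000 nM as a limit of the assay
- Compound 2 `C=C1C(=O)O[C@H]2CC3=C[C@H](C/C(C)=C/[C@@H](OC(=O)CCCCBr)[C@H]12)OC3=O` gives > 10000 nM as a limit of the assay
- Compound 3 `C=C1C(=O)O[C@H]2CC3=C[C@H](C/C(C)=C/[C@@H](OC(=O)CC4CCCCC4)[C@H]12)OC3=O` gives 2000 nM as a measured number

These compounds share one core and differ in the group on a carbonyl carbon. For the measured compounds named here, in a functional assay on NCI-H460 cells (Homo sapiens) for cytotoxicity, read by MTT assay, with a stated time of 48 h (on this read-out lower numbers stand for stronger inhibition and higher numbers for weaker inhibition), compound 3 is the only one with a true number, which makes it the natural starting point. Two measured steps lead to it: an at least 5.0-fold lower number from compound 1 to compound 3 (0.69 log units; beyond the scatter) and an at least 5.0-fold lower number from compound 2 to compound 3 (0.69 log units; beyond the scatter). Each of these sizes is only a minimum.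

Compound 4 `C=C1C(=O)O[C@H]2CC3=C[C@H](C/C(C)=C/[C@@H](OC(=O)C4CCC(F)(F)CC4)[C@H]12)OC3=O` has not yet been measured. Its structural change from compound 3 is this: 4,4-difluorocyclohexyl in place of cyclohexylmethyl on a carbonyl carbon. Both groups hold one six-membered non-aromatic ring of carbon only.

The two measured steps show that changing this group can move the number beyond the scatter. However, neither step involves fluorine or this exact exchange. Compound 4 keeps the ring of compound 3, which gives 2000 nM in this assay, so a nearby result is expected. Going by the values given here, the expected change is small: a 1.5-fold higher number from compound 3 to compound 4 (0.18 log units; within the scatter), with no step clearly beyond the scatter. The estimate for compound 4 is 3000 nM, with an expected range of 1000 nM to 9000 nM.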

Compound 4, half-maximal inhibitory concentration: > 10000 nM
Compound 4 ended at the assay's limit; the forecaster's own chance of this, stated with the estimate: 20%; middle value at least 3.3-fold (0.52 log units) away from the limit.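

In this assay, this exchange gives an at least 5.0-fold higher number from compound 3 to compound 4 (0.69 log units; beyond the scatter), so two groups that each hold one six-membered non-aromatic ring of carbon only do not behave alike on this carbonyl carbon. The earlier steps shown here could not show this, as they set the cyclohexylmethyl group of compound 3 against 4-(trifluoromethyl)phenyl and 4-bromobutyl, groups of a different kind, whereas here a carbon ring stays in place and the measurable effect of compound 3 still falls out of the assay's range. For the compounds shown here, compound 3 therefore remains the only compound with a true number, and the steps from compound 1 and compound 2 to compound 4 cannot be read, as the values at both ends are limits: the limit of > 10000 nM in this assay, at which 3 of the 4 values shown sit.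

On these data alone, what stays open is how far compound 4 lies past its limit, and which part of the exchange matters: the loss of the methyl link of cyclohexylmethyl or the entry of two fluorine atoms. A plain cyclohexyl group or a 4,4-difluorocyclohexylmethyl group on this carbonyl carbon would be the comparison that separates the two.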